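Swapping the anilide ring on the shared thiazolidinedione core

The compounds below may be only part of what the source reports. "The series", "measured", "known", "first", "only" and "open" are said of these compounds alone.

Of the compounds shown here, three sharing one core have been measured in an assay on isolated protein for inhibition of histone deacetylase 4 (Homo sapiens), with a stated time of 1 h; a higher number here means a weaker inhibitor, a lower number a stronger inhibitor. Compound 1 `O=C(COc1ccc2cc(/C=C3/SC(=O)NC3=O)ccc2c1)Nc1cccc(Cl)c1` gives 3800 nM, the second highest of the three numbers. Compound 2 `O=C(COc1ccc2cc(/C=C3/SC(=O)NC3=O)ccc2c1)Nc1cc(Cl)cc(C(F)(F)F)c1` gives 4000 nM, and the step of a 1.1-fold higher number from compound 1 to compound 2 (0.02 log units; within the scatter) shows no effect beyond the scatter. Compound 3 `O=C(COc1ccc2cc(/C=C3/SC(=O)NC3=O)ccc2c1)Nc1c(F)cc(F)cc1Br` gives 1100 nM, and the steps of a 3.5-fold lower number from compound 1 to compound 3 (0.54 log units; beyond the scatter) and a 3.6-fold lower number from compound 2 to compound 3 (0.56 log units; beyond the scatter) are modest gains.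

Compound 4 `O=C(COc1ccc2cc(/C=C3/SC(=O)NC3=O)ccc2c1)Nc1ccc(Br)cc1F` has not yet been measured. It differs from compound 1 in one place: 4-bromo-2-fluorophenyl in place of 3-chlorophenyl on an amide-type nitrogen. The step from compound 1 to compound 3 bears on this change most directly, since it also exchanges the 3-chlorophenyl for a ring carrying bromine and fluorine, and it was modest in size. Going by the values given here, no measured step puts a 4-bromo-2-fluorophenyl on the amide-type nitrogen, so the estimate is cautious. Compound 4 is therefore expected to give a somewhat lower number than compound 1, with the step of a 1.7-fold lower number from compound 1 to compound 4 (0.24 log units; within the scatter) being estimated. The estimate for compound 4 in this assay is 2200 nM, in the range 900 nM to 5500 nM.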

Compound 4, half-maximal inhibitory concentration: 1900 nM
For compound 4 the middle estimate is 1.2-fold (0.06 log units) above the measured one; low and high end bracket the measured number.
By their numbers in this assay, from the lowest: compounds 3, 4, 1 and 2 (each within the scatter of the next, the first and the last beyond it).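

The 4-bromo-2-fluorophenyl group puts compound 4 in an intermediate place on this amide-type nitrogen: a 1.7-fold higher number from compound 3 to compound 4 (0.24 log units; within the scatter) and a 2.0-fold lower number from compound 1 to compound 4 (0.30 log units; within the scatter) both stay within the scatter, so compound 4 cannot be separated from either of the two compounds that the earlier data did separate. Only a 2.1-fold lower number from compound 2 to compound 4 (0.32 log units; beyond the scatter) goes beyond the scatter, and it is modest, so a second ring carrying bromine and fluorine gives a small gain over compound 2 but no clear gain over compound 1. Nothing available explains these differences.

The compounds shown do not separate the contribution of the bromine from that of the fluorine, since no ring here carries only one of them. They also leave open how an amine, a carboxylic acid or a methoxy group on this ring would behave.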